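Fluoro for chloro on the pyrazoline-linked phenyl

The source may report more compounds than this note shows. Statements on the series, on what has been measured and on what is new or still open speak of the compounds shown alone.

Two members of this series have numbers in a functional assay on the whole organism (strain Wistar) for inhibition, with Rattus norvegicus as the target, read by paw edema, with stated times of 30 min and 120 min, at a dose of 50 mg/kg by the oral route (a higher number here means more inhibition at the dose given (going by the name of the read-out), a lower number less inhibition), so far. Compound 1 `O=CN1N=C(c2ccc(F)cc2)CC1c1cn(-c2ccccc2)nc1-c1ccc(Cl)c(Cl)c1` gives 60.9% in this assay. Compound 2 `Clc1ccc(C2=NNC(c3cn(-c4ccccc4)nc3-c3ccc(Cl)c(Cl)c3)C2)cc1` gives 48.4% and stands lowest of the two, its nearest neighbour compound 1 sitting higher by a margin beyond the scatter. Compound 3 `Fc1ccc(C2=NNC(c3cn(-c4ccccc4)nc3-c3ccc(Cl)c(Cl)c3)C2)cc1` has not been measured; it differs from compound 2 by fluoro in place of chloro on an aromatic carbon. Going by the values given here, no step between measured compounds covers this change, so only a small step is expected, if any, from compound 2 to compound 3, a number 3.6 percentage points higher from compound 2 to compound 3 (within the scatter), most likely within the scatter. Compound 3 is estimated at 52%, between 40% and 65%.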

Compound 3, a percentage reported as inhibition, in the whole organism at one dose (the size of the read-out at that dose, not a potency): 46.1%
The estimate for compound 3 lay 5.9 percentage points above the measured number; low and high end bracket the measured number.
By their numbers in this assay, from the lowest: compounds 3 and 2 (each within the scatter of the next); then compound 1.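

In this assay, the change from 4-chlorophenyl to 4-fluorophenyl gives a number 2.3 percentage points lower from compound 2 to compound 3 (within the scatter) and so does not separate these two compounds. The formyl on the ring amine nitrogen now has a comparison in one place, as hydrogen there gives a number 14.8 percentage points lower from compound 1 to compound 3 (beyond the scatter) and marks that nitrogen as the position where the number moves. Nothing measured on these compounds explains either step. Still open, on these data alone, is whether an acetyl group on that nitrogen would hold the number of compound 1, and whether a methoxy group in place of the halogen on the phenyl would shift it.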